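The source may hold more compounds than are shown below. What is called first, only, known or untested is meant among the compounds shown, and "the series" means these compounds.

In a functional assay on HeLa cells (Homo sapiens) for cytotoxicity, read by XTT assay, with a stated time of 24 h (on this read-out higher numbers stand for weaker inhibition and lower numbers for stronger inhibition), compound 1 (`Cc1cc(Cl)c2c(c1O)C(=O)C=CC2=O`) gives 10100 nM and compound 2 (`COc1cc(C)c(Cl)c2c1C(=O)C=CC2=O`) gives 19100 nM, so the two stand within the usual scatter of each other. Compound 3 (`CCOc1c(C)cc(Cl)c2c1C(=O)C=CC2=O`) has not yet been measured. It differs from compound 1 by ethyl in place of hydrogen on an oxygen on an aromatic ring, hydroxy to ethoxy, on an oxygen on an aromatic ring. Among the measured compounds shown here, no measured step shows this change, so in this assay no shift beyond the scatter is expected, if anything a slightly higher number. The estimated change is a 1.5-fold higher number from compound 1 to compound 3 (0.17 log units; within the scatter). For compound 3 the expected value is 15000 nM, within an estimated range of 6000 nM to 40000 nM.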

Compound 3, half-maximal inhibitory concentration: 33200 nM
For compound 3 the middle estimate is 2.2-fold (0.35 log units) below the measured one; measured number inside the range.
By their numbers in this assay, from the lowest: compounds 1, 2 and 3 (each within the scatter of the next, the first and the last beyond it).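

In this assay the change of hydroxy to ethoxy gives a 3.3-fold higher number from compound 1 to compound 3 (0.52 log units; beyond the scatter) and so the first step beyond the scatter among these compounds, though a modest one. It shows that, on an oxygen on an aromatic ring, ethyl in place of hydrogen goes with weaker inhibition. Nothing available accounts for this shift. The compounds shown leave open whether a longer chain such as butyl on this oxygen would move the number further, and how an amine in place of the ethoxy would read.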